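The source may hold more compounds than are shown below. What is called first, only, known or untested is meant among the compounds shown, and "the series" means these compounds.

Measured in an assay on isolated protein for inhibition of G protein-coupled receptor kinase 6 (Homo sapiens), read by scintillation counting, radiometric assay and 33P incorporation, with a stated time of 80 min, in the presence of a further agent that is not named here; a lower number here means a stronger inhibitor, a higher number a weaker inhibitor:
compound 1 `CCc1cc(Nc2nc(NCc3ccc(F)cc3)nc3ccccc23)n[nH]1` gives 250 nM
compound 2 `CCc1cc(Nc2nc(N[C@@H](C)c3ccc(F)cn3)nc3cccc(F)c23)n[nH]1` gives 29 nM
compound 3 `CCc1cc(Nc2nc(N[C@@H](C)c3ccc(C)cc3)nc3cccc(F)c23)n[nH]1` gives 27 nM

Compound 3 stands with the lowest number of the three in this assay. Its nearest neighbour is compound 2, whose number in this assay is within the scatter of that of compound 3; compound 1, with the shared core lacking the fluorine on the fused ring and the methyl on the chain carbon, gives a clearly higher number. Compound 4 `CCc1cc(Nc2nc(N[C@@H](C)c3ncc(F)cn3)nc3cccc(F)c23)n[nH]1` differs from compound 3 in a single place: 5-fluoropyrimidin-2-yl in place of 4-methylphenyl on a saturated chain carbon bound to a nitrogen on an aromatic ring and a saturated chain carbon. Going by the values given here, the one measured step that bears on this exchange is a 1.1-fold lower number from compound 2 to compound 3 (0.03 log units; within the scatter), where a fluorinated six-membered ring with one nitrogen was replaced by 4-methylphenyl and the number hardly moved. Compound 4 returns to a fluorinated six-membered ring, now with two nitrogens, so on this evidence a step of a 1.3-fold higher number from compound 3 to compound 4 (0.11 log units; within the scatter) is expected, that is, no change beyond the scatter. The number for compound 4 in this assay is therefore estimated at 35 nM, with a range from 15 nM to 80 nM.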

Compound 4, half-maximal inhibitory concentration: 230 nM
Compound 4: the middle estimate sits 6.6-fold (0.82 log units) below what was measured, outside the stated range (above it).
By their numbers in this assay, from the lowest: compounds 3 and 2 (each within the scatter of the next); then compounds 4 and 1 (each within the scatter of the next).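

In this assay, the ring on this saturated chain carbon turns out to matter: putting 5-fluoropyrimidin-2-yl in place of 4-methylphenyl brings an 8.5-fold higher number from compound 3 to compound 4 (0.93 log units; beyond the scatter) and so gives a weaker inhibitor, although 5-fluoropyridin-2-yl and 4-methylphenyl had stood within the scatter of each other. Against the fluorinated ring with one nitrogen, the exchange brings a 7.9-fold higher number from compound 2 to compound 4 (0.90 log units; beyond the scatter) as well, so among these compounds a fluorinated ring as such does not go with the weaker number, while the ring with 2 hetero atoms does. Nothing available here accounts for this difference.

Going by these compounds, what an unsubstituted pyrimidin-2-yl or a 5-methylpyrimidin-2-yl would give at this place remains open, so the part played by the fluorine on the new ring stays unsettled. Equally open, on these data alone, is how a saturated ring such as cyclohexyl would behave on the same carbon.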